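Trifluoroethoxy in place of trifluoromethoxy on the aryl ether

The source may report more compounds than this note shows. Statements on the series, on what has been measured and on what is new or still open speak of the compounds shown alone.

Measured so far in a functional assay on U-373MG ATCC cells (Homo sapiens) for inhibition, read by MTT assay, with a stated time of 72 h; on this read-out lower numbers stand for stronger inhibition and higher numbers for weaker inhibition:
compound 1 `O=C(NNC(=O)C1CC1c1ccc(OC(F)(F)F)cc1)c1ccncc1` gives 37000 nM
compound 2 `O=C(NNc1nncc2ccccc12)C1CC1c1ccc(OCC(F)(F)F)cc1` gives 25000 nM
compound 3 `CC(C)=CCC/C(C)=C/COc1ccc(C2CC2C(=O)NNc2nncc3ccccc23)cc1` gives 9000 nM

Compound 1 stands at the highest number of the three. Its gap to compound 2 is within the scatter; its gap to compound 3 is beyond it. Within the data shown here, the one single-place step that has been measured, a 2.8-fold lower number from compound 2 to compound 3 (0.44 log units; beyond the scatter), concerns a different replacement at the same aryl oxygen and runs between compounds that differ from compound 1 elsewhere in the molecule, so it does not bear directly on the change at hand.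

Compound 4 `O=C(NNC(=O)C1CC1c1ccc(OCC(F)(F)F)cc1)c1ccncc1` is compound 1 with 2,2,2-trifluoroethyl in place of trifluoromethyl on an oxygen on an aromatic ring. Among the measured compounds shown here, no measured pair isolates this change. Compound 2 carries the same 2,2,2-trifluoroethoxy group and lies within the scatter of compound 1, which is the only indirect hint available and points to no step beyond the scatter. Compound 4 is therefore expected to give about 30000 nM, between 12000 nM and 80000 nM, an estimated step of a 1.2-fold lower number from compound 1 to compound 4 (0.09 log units; within the scatter).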

Compound 4, half-maximal inhibitory concentration: 19000 nM
Estimate against measurement, compound 4: 1.6-fold (0.20 log units) above, and the stated range covers the measured number.
By their numbers in this assay, from the lowest: compound 3; then compounds 4, 2 and 1 (each within the scatter of the next).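

In this assay, among these compounds, this pair isolates the replacement at the aryl oxygen for the first time: a 1.9-fold lower number from compound 1 to compound 4 (0.29 log units; within the scatter). On the core of compound 1, 2,2,2-trifluoroethyl can therefore stand in place of trifluoromethyl on the oxygen without a step beyond the scatter, and compound 1 and compound 4 cannot be told apart in this read-out. Nothing available bears on the reason for this result.

Open, on these data alone, is whether the same replacement reads alike on the core of compound 2, which already carries 2,2,2-trifluoroethoxy. Also open, as far as these compounds go, is whether a longer fluorinated chain such as 3,3,3-trifluoropropyl, or a chain ending in an amine or a carboxylic acid, on the same oxygen would give a step beyond the scatter from compound 1.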